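The source may report more compounds than this note shows. Statements on the series, on what has been measured and on what is new or still open speak of the compounds shown alone.

Compound 2 `O=C(/C=C/c1ccccc1)Nc1cc(Sc2ncn[nH]2)c(O)c2ccccc12` belongs to a small group of compounds that share one core and differ only in the group on the carbonyl carbon of the amide. In a functional assay on MDA-MB-231 cells (Homo sapiens) for antiproliferative activity, read by MTT assay, with a stated time of 48 h (on this read-out lower numbers stand for stronger inhibition and higher numbers for weaker inhibition), compound 2 gives > 100000 nM, which is a limit of the assay rather than a number. Compound 1 `O=C(Nc1cc(Sc2ncn[nH]2)c(O)c2ccccc12)c1cccc(Cl)c1`, carrying 3-chlorophenyl on that carbonyl carbon, is the other measured member. In this assay compound 1 gives > 100000 nM, again a limit of the assay. Going by the values given here, the one measured step, a step that the two limits leave unreadable from compound 1 to compound 2, cannot be read in size, since both of its ends sit at the limit; the only evidence is the limit of > 100000 nM in this assay, at which 2 of the 2 values shown sit.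

Compound 3 `O=C(Nc1cc(Sc2ncn[nH]2)c(O)c2ccccc12)c1ccc(Cl)cc1` is the next member. Its change from compound 2 is 4-chlorophenyl in place of 2-phenylethenyl on a carbonyl carbon. The measured step does not show any size, so there is no ground to expect that moving to 4-chlorophenyl lifts the compound off the limit. Compound 3 is therefore expected to give about 150000 nM in this assay, within 30000 nM to 600000 nM, a step that the limit leaves unreadable from compound 2 to compound 3 that is itself expected to remain unreadable, with the result most likely reported as a limit again.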

Compound 3, half-maximal inhibitory concentration: 25700 nM
Beside the measured number, compound 3's estimate is 5.8-fold (0.77 log units) above it; measured number outside the range, below it.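

With compound 3, the group on the carbonyl carbon of the amide first gives a readable number in this assay: compound 3, carrying 4-chlorophenyl, gives 25700 nM, so this shared core can show measurable antiproliferative activity with the right group at this place. Putting 4-chlorophenyl in place of 2-phenylethenyl gives an at least 3.8-fold lower number from compound 2 to compound 3 (0.59 log units; beyond the scatter), and putting it in place of 3-chlorophenyl gives an at least 3.8-fold lower number from compound 1 to compound 3 (0.59 log units; beyond the scatter), so the second step shows that the place of the chlorine on the phenyl ring alone separates a measured compound from one at the limit. These two sizes are only lower bounds and the step between compound 1 and compound 2 still cannot be read, since the values of those two compounds are limits and not numbers: the limit of > 100000 nM in this assay, at which 2 of the 3 values shown sit.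

The compounds shown leave open whether other groups on the phenyl ring at the same place, such as 4-fluorophenyl or 4-methoxyphenyl, would give lower or higher numbers than compound 3. They also leave open what a non-aromatic group on the carbonyl carbon, such as a longer carbon chain or one ending in an amine, would do in this assay.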